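The compounds below may be only part of what the source reports. "The series", "measured", "known", "first", "only" and "open" are said of these compounds alone.

Working notes on the series, read in a toxicity assay on C8166 cells (Homo sapiens) for cytotoxicity, read by MTT assay, with a stated time of 72 h; a higher number here means that more compound is tolerated, a lower number that less compound is tolerated. Compound 1 `O=C(NCc1ccc(F)cc1)c1nc(NCCO)c2cccnc2c1O` gives 91000 nM. Compound 2 `NCCNc1c(C(=O)NCc2ccc(F)cc2)nc(Br)c2cccnc12` supplies no number, and its entry reads "not determined" (no result reported). Among the compounds with values here, compound 3 `C[C@@H](CO)Nc1nc(C(=O)NCc2ccc(F)cc2)c(O)c2ncccc12` gives 107000 nM, and compound 1 is the only other number available for comparison. The two values lie within the scatter of each other, so no order can be drawn between them.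

Compound 4 `C[C@H](CO)Nc1nc(C(=O)NCc2ccc(F)cc2)c(O)c2ncccc12` is the open entry. Its change from compound 3 is the two compounds have the same atoms and bonds and differ only in configuration as drawn: 1 of 1 stereo elements differ; a stereocentre at a saturated chain carbon is drawn S in compound 3 and R in compound 4: a stereocentre at a saturated chain carbon is drawn S in compound 3 and R in compound 4.

Within the data shown here, one measured step bears on this place, the methyl in place of hydrogen on that saturated chain carbon. That step is a 1.2-fold higher number from compound 1 to compound 3 (0.07 log units; within the scatter), and it stays within the scatter. Among the measured compounds shown here, it covers only the S form, and no measured pair compares the two configurations, so the support is thin. On that evidence, no change beyond the scatter is expected in this assay, and no direction is favoured.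

The estimate is a 1.1-fold lower number from compound 3 to compound 4 (0.03 log units; within the scatter). For compound 4 the expected value is 100000 nM, with an estimated range of 50000 nM to 200000 nM.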

Compound 4, half-maximal cytotoxic concentration: 69000 nM
For compound 4 the middle estimate is 1.4-fold (0.16 log units) above the measured one, within the range that was stated.
By their numbers in this assay, from the lowest: compounds 4, 1 and 3 (each within the scatter of the next).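

The configuration at the saturated chain carbon now has a direct comparison in this assay, with a 1.6-fold lower number from compound 3 to compound 4 (0.19 log units; within the scatter), so the two drawn forms do not separate at this place. Methyl in place of hydrogen on that carbon can now be read in both forms: the R form gives a 1.3-fold lower number from compound 1 to compound 4 (0.12 log units; within the scatter), and the S form gives a 1.2-fold higher number from compound 1 to compound 3 (0.07 log units; within the scatter), so neither form takes the number outside the scatter. The comparison of the two forms bears on the stereocentre alone, because nothing else separates the two structures: the fact that compounds 3 and 4 differ only in the configuration as drawn.

Open, from the compounds shown here alone, is whether a larger group on this carbon, such as ethyl or a longer chain, would give a step beyond the scatter in this assay, and whether the two configurations would then still fall within the scatter of each other. Also open, going by these compounds, is whether a carboxylic acid in place of the chain hydroxyl would leave the number where compounds 1, 3 and 4 stand.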